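This account rests on a few compounds, and the source may have more. Where it says the series, first, only, none or still open, it means among the compounds named here.

Measured so far in an ADME assay on microsomes from liver (Mus musculus) for pharmacokinetics; on this read-out higher numbers stand for fast clearance and lower numbers for slow clearance:

- Compound 1 `C[C@H](NC(=O)CC(F)(F)F)c1ccc(NC(=O)[C@H]2C[C@@H]2c2cccnc2)cc1`: 83.7 mL.min-1.g-1
- Compound 2 `C[C@H](NC(=O)[C@@H]1CCCN1C)c1ccc(NC(=O)[C@H]2C[C@@H]2c2cccnc2)cc1`: 65.4 mL.min-1.g-1
- Compound 3 `C[C@H](NC(=O)c1ccccc1)c1ccc(NC(=O)[C@H]2C[C@@H]2c2cccnc2)cc1`: 148 mL.min-1.g-1

Compound 2 shares the low end of this small set with compound 1, as the step of a 1.3-fold lower number from compound 1 to compound 2 (0.11 log units; within the scatter) does not separate them. Only compound 3 stands clear of compound 2, with the step of a 2.3-fold higher number from compound 2 to compound 3 (0.35 log units; beyond the scatter).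

The next compound is compound 4 `C[C@H](NC(=O)c1ccccn1)c1ccc(NC(=O)[C@H]2C[C@@H]2c2cccnc2)cc1`, which has pyridin-2-yl in place of 1-methylpyrrolidin-2-yl on a carbonyl carbon. Within the data shown here, no measured compound carries pyridin-2-yl, so the expectation has to rest on its neighbours. The closest guide is compound 3, where phenyl takes the place of the same group at the same carbonyl carbon. That step is modest, and it is the only one of the three to pass beyond the scatter. The remaining step, a 1.8-fold higher number from compound 1 to compound 3 (0.25 log units; within the scatter), stays within it. Across these three compounds, changes at this carbonyl carbon have therefore produced only small steps.

A rise in the same direction as the step to compound 3 is expected, but a smaller one that probably stays within the scatter. The expected step is a 1.5-fold higher number from compound 2 to compound 4 (0.18 log units; within the scatter). The estimated value for compound 4 is 100 mL.min-1.g-1, with an expected range of 55 mL.min-1.g-1 to 175 mL.min-1.g-1.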

Compound 4, intrinsic clearance in microsomes: < 3.42 mL.min-1.g-1
Compound 4 gave a limit, no number; the forecaster's own chance of this, stated with the estimate: 2%; at least 29-fold (1.46 log units) between middle value and limit.
By their numbers in this assay, from the lowest: compounds 2, 1 and 3 (each within the scatter of the next, the first and the last beyond it). At a limit, below all of these: compound 4.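

In this assay compound 4 gave only a limit, not a number: the limit of < 3.42 mL.min-1.g-1 in this assay, at which 1 of the 4 values shown sits. The earlier groups on this carbonyl carbon, 2,2,2-trifluoroethyl, 1-methylpyrrolidin-2-yl and phenyl, had produced only small to modest steps, whereas pyridin-2-yl sets compound 4 apart from all three, with an at least 19-fold lower number from compound 2 to compound 4 (1.28 log units; beyond the scatter), an at least 43-fold lower number from compound 3 to compound 4 (1.63 log units; beyond the scatter) and an at least 24-fold lower number from compound 1 to compound 4 (1.38 log units; beyond the scatter). This position can therefore carry a large change in this read-out, and an aromatic ring here is not enough to give it, as compound 3, which carries phenyl, has the highest number of the set at 148 mL.min-1.g-1.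

From the compounds shown here alone, it remains open whether pyridin-3-yl or pyridin-4-yl on this carbonyl carbon would fall with pyridin-2-yl or stay with phenyl, and so whether the place of the ring nitrogen matters. Going by these compounds, how far compound 4 lies past its limit also remains open, so the full size of its three steps is unknown.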